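The source may hold more compounds than are shown below. What is called first, only, known or untested is meant among the compounds shown, and "the series" means these compounds.

compound 1 `O=C(CCCCCCNC(=O)C(O)(O)C(F)(F)F)Nc1ccccc1`: 9140 nM
compound 2 `O=C(CCCCCCNC(=O)C(O)(O)C(F)(F)F)Nc1ccc(-c2ccccc2)cc1`: 4730 nM

In a functional assay on HCT-116 cells (Homo sapiens) for inhibition, read by colorimetric assay, with a stated time of 3 days (a lower number here means a stronger inhibitor, a higher number a weaker inhibitor), compound 2 gives 4730 nM, which cannot be told apart from the value of compound 1. Among the measured compounds shown here, the one measured step, which puts phenyl in place of hydrogen on an aromatic carbon, is a 1.9-fold lower number from compound 1 to compound 2 (0.29 log units; within the scatter).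

The next compound, compound 3 `Cc1ccc(S(=O)(=O)Nc2ccc(NC(=O)CCCCCCNC(=O)C(O)(O)C(F)(F)F)cc2)cc1`, has not yet been measured. Its change from compound 2 is ((4-methylphenyl)sulfonyl)amino in place of phenyl on an aromatic carbon, para to a large group: ((4-methylphenyl)sulfonyl)amino in place of phenyl on an aromatic carbon.

For the measured compounds named here, no measured compound carries this new group, so the single step above is only a loose guide. It stayed within the scatter, so no shift beyond the scatter is expected here, in either direction. The expected change is a 1.1-fold lower number from compound 2 to compound 3 (0.02 log units; within the scatter). Compound 3 is estimated at 4500 nM, with an expected range of 1500 nM to 13000 nM.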

Compound 3, half-maximal inhibitory concentration: 17200 nM
For compound 3 the middle estimate is 3.8-fold (0.58 log units) below the measured one; the measured number lies above the stated range.
By their numbers in this assay, from the lowest: compounds 2, 1 and 3 (each within the scatter of the next, the first and the last beyond it).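

Among the compounds shown here, the aromatic carbon para to a large group can separate two substituents in this assay: replacing phenyl with ((4-methylphenyl)sulfonyl)amino gives a 3.6-fold higher number from compound 2 to compound 3 (0.56 log units; beyond the scatter), the first step here beyond the scatter. Yet the same group in place of hydrogen gives a 1.9-fold higher number from compound 1 to compound 3 (0.27 log units; within the scatter), so compound 3 cannot be told apart from compound 1, and the only clear gap lies between the two larger groups, each of which carries a six-membered aromatic ring of carbon only. Nothing available here explains that gap.

The compounds shown leave open whether the sulfonyl link, the amide-like hydrogen on its nitrogen or the 4-methyl group accounts for the step. They also leave open how an amine or a carboxylic acid would read at this same carbon.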